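The source may report more compounds than this note shows. Statements on the series, on what has been measured and on what is new or still open speak of the compounds shown alone.

In a functional assay on MKN-74 cells (Homo sapiens) for antiproliferative activity, with a stated time of 24 h (a lower number here means a stronger inhibitor, a higher number a weaker inhibitor), compound 2 `NC(=O)c1c(NC(=O)c2ccccc2F)sc2c1CCN(Cc1c(Cl)cccc1Cl)C2` gives 7430 nM, the lowest number of the three measured compounds, although compound 1 `NC(=O)c1c(NC(=O)c2ccc(C(F)(F)F)cc2)sc2c1CCN(Cc1c(Cl)cccc1Cl)C2` with 8530 nM and compound 3 `NC(=O)c1c(NC(=O)c2cccc([N+](=O)[O-])c2)sc2c1CCN(Cc1c(Cl)cccc1Cl)C2` with 13500 nM sit within the scatter of it, as the steps of a 1.1-fold lower number from compound 1 to compound 2 (0.06 log units; within the scatter) and a 1.8-fold higher number from compound 2 to compound 3 (0.26 log units; within the scatter) show, so compound 2 cannot be called the strongest. Compound 4 `NC(=O)c1c(NC(=O)c2ccccc2F)sc2c1CCN(C(=O)Nc1ccccc1Cl)C2` changes a different part of the shared core: (2-chlorophenyl)carbamoyl in place of 2,6-dichlorobenzyl on an amine nitrogen in a ring. Every measured step, including a 1.6-fold higher number from compound 1 to compound 3 (0.20 log units; within the scatter), swaps only the group on the carbonyl carbon and stays within the scatter, so nothing measured bears directly on this exchange. The expectation is therefore a step of a 1.1-fold higher number from compound 2 to compound 4 (0.03 log units; within the scatter) of no clear direction, with a wide range, and compound 4 is estimated at 8000 nM, between 2000 nM and 30000 nM.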

Compound 4, half-maximal inhibitory concentration: 49600 nM
The estimate for compound 4 lay 6.2-fold (0.79 log units) below the measured number, and the stated range ends below it.
By their numbers in this assay, from the lowest: compounds 2, 1 and 3 (each within the scatter of the next); then compound 4.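

At the amine nitrogen in the ring, the exchange of 2,6-dichlorobenzyl for (2-chlorophenyl)carbamoyl gives, in this assay, a 6.7-fold higher number from compound 2 to compound 4 (0.82 log units; beyond the scatter) and so a weaker inhibitor. This is the first step shown that lies beyond the scatter, whereas the exchanges on the carbonyl carbon all stayed within it. No measurement at hand explains this step. The compounds shown leave open whether the carbamoyl link or the missing second chlorine carries the step. A 2-chlorobenzyl group on this nitrogen would separate the two.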